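Compound 3: trifluoromethyl to 1,1,2,2,2-pentafluoroethyl

The source may report more compounds than this note shows. Statements on the series, on what has been measured and on what is new or still open speak of the compounds shown alone.

In a physicochemical assay for lipophilicity, at pH 7.4 (a lower number here means a more polar compound, a higher number a more lipophilic compound), compound 3 `CN1C(=O)[C@@H](NC(=O)c2n[nH]c3ncc(C(F)(F)F)cc23)COc2ccccc21` gives 3.3, the highest of the three numbers and beyond the scatter of both others. Compound 4 `CN1C(=O)[C@@H](NC(=O)c2n[nH]c3ncc(C(F)(F)C(F)(F)F)cc23)COc2ccccc21` differs from it in one place: trifluoromethyl in place of fluoro on a saturated chain carbon bound to an aromatic carbon and two fluorine atoms. Within the data shown here, no measured pair isolates this change. Among the measured compounds shown here, the only rough guide to size is the gap between compound 1 `CN1C(=O)[C@@H](NC(=O)c2nnn3c2C[C@H](C(F)(F)F)CC3)COc2ccccc21` at 1.5 and compound 2 `CN1C(=O)[C@@H](NC(=O)c2nnn3c2CC(C(F)(F)C(F)(F)F)CC3)COc2ccccc21` at 2. The expected step in this assay is a number 0.50 log units higher from compound 3 to compound 4 (beyond the scatter), upward and of similar size, beyond the scatter. Compound 4 is estimated at 3.8, with an expected range of 3.4 to 4.3.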

Compound 4, distribution coefficient: 4.1
For compound 4 the middle estimate is 0.30 log units below the measured one, within the range that was stated.
By their numbers in this assay, from the lowest: compound 1; then compound 2; then compound 3; then compound 4.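

In this assay going from trifluoromethyl to 1,1,2,2,2-pentafluoroethyl gives a number 0.80 log units higher from compound 3 to compound 4 (beyond the scatter) on the shared core. Among these compounds, this is the first matched pair for this change at this position, so the step belongs to the chain extension alone. Nothing measured here accounts for its size.

Open, on these data alone, is whether a longer chain, such as heptafluoropropyl, would extend the step in the same direction. Also open, as far as these compounds go, is how an amine or a carboxylic acid in this place would read in this assay on the same core.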